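Methoxy analogue of compound 1 in the cytotoxicity series

A few compounds are considered here, and "the series" means these few. Any claim that something is new, unique, unknown or untested is made for them only; others in the source may bear on it.

Measured so far:
compound 1 `O=c1[nH]nc2n(c1=O)CCN2c1ccccc1` — 0%
compound 2 `Cc1ccc(N2CCn3c2n[nH]c(=O)c3=O)cc1` — 22%
compound 3 `Cc1cccc(N2CCN/C2=N\N)c1C` — 25%

In a functional assay on T47D cells (Homo sapiens) for cytotoxicity, with a stated time of 72 h, tested at 50 ug/mL (on this read-out higher numbers stand for a stronger effect at the one concentration tested and lower numbers for a weaker effect), compound 1 gives 0%, the lowest of the three numbers; compound 2 is the nearest and compound 3, with a different core, the furthest. For the measured compounds named here, the only step between compounds that differ in one place is a number 22 percentage points higher from compound 1 to compound 2 (beyond the scatter). Compound 4 `COc1ccccc1N1CCn2c1n[nH]c(=O)c2=O` carries methoxy in place of hydrogen on an aromatic carbon, sitting on an aromatic carbon of a six-membered aromatic ring of carbon only, ortho to a large group. Going by the values given here, the methyl step gives the only guide, and a group on a different aromatic carbon need not repeat it, so a small to modest rise is expected. Compound 4 is estimated at 14% (range 0% to 32%), meaning an expected step of a number 14 percentage points higher from compound 1 to compound 4 (beyond the scatter).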

Compound 4, a percentage reported as inhibition, at one concentration (the size of the read-out at that concentration, not a potency): 9%
For compound 4 the middle estimate is 5 percentage points above the measured one; the range from low to high includes it.
By their numbers in this assay, from the lowest: compounds 1 and 4 (each within the scatter of the next); then compounds 2 and 3 (each within the scatter of the next).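

In this assay the step of a number 9 percentage points higher from compound 1 to compound 4 (within the scatter) shows that methoxy on an aromatic carbon, ortho to a large group, is not separable from hydrogen at this position. The methyl step a number 22 percentage points higher from compound 1 to compound 2 (beyond the scatter) involves a different group on a different aromatic carbon, so the pair of steps does not separate the effect of the group from that of its place. Nothing available accounts for the size of the methoxy step. Still open, from the compounds shown here alone, is whether methoxy on the aromatic carbon bearing the methyl of compound 2 would give a step beyond the scatter. Also open, going by these compounds, is how an amine or a carboxylic acid, ortho to a large group, would read.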